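A few compounds are considered here, and "the series" means these few. Any claim that something is new, unique, unknown or untested is made for them only; others in the source may bear on it.

Measured compounds:
Compound 1 `COc1ccc([S+]([O-])c2cn(-c3ccc4c(c3)B(O)OC4)c3ccccc23)cc1` gives in an ADME assay on L929 cells (Mus musculus) for cytotoxicity, read by resazurin assay, with a stated time of 72 h (a lower number here means a stronger inhibitor, a higher number a weaker inhibitor), the value > 10 ug/mL, which is a limit of the assay and not a number.
Compound 2 `CNC(=O)c1cccn1-c1ccc2c(c1)B(O)OC2` gives in this assay the value > 10 ug/mL, again a limit of the assay.
Compound 3 `O=C(c1ccc(F)cc1)c1ccn(-c2ccc3c(c2)B(O)OC3)c1` gives in this assay the value > 10 ug/mL, also a limit of the assay.

All three measured compounds share the same core, and none of them reaches a numeric reading: every one sits at the limit of > 10 ug/mL in this assay, at which 3 of the 3 values shown sit. Compound 3 therefore cannot be placed above or below the other two; it stands where they stand, at the limit.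

The piece now turns to compound 4 `O=C(c1ccc(CO)cc1)c1ccn(-c2ccc3c(c2)B(O)OC3)c1`, which has not yet been measured in this assay. It differs from compound 3 in one place: hydroxymethyl in place of fluoro on an aromatic carbon. Within the data shown here, no measured pair in this set shows what such a change does in this assay, so no direction can be read from the data. Given that compound 3 sits at the limit, the step from compound 3 to compound 4 is expected to be small, none beyond the scatter, so that a step that the limit leaves unreadable from compound 3 to compound 4 is the estimate of that step. For compound 4 the expected value in this assay is 15 ug/mL, within the range from 8 ug/mL to 40 ug/mL, most likely reported again only as a limit.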

Compound 4, half-maximal inhibitory concentration: 9.31 ug/mL
Compound 4: the middle estimate sits 1.6-fold (0.21 log units) above what was measured; measured number inside the range.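

Among these compounds, with hydroxymethyl in place of fluoro on an aromatic carbon para to a large group, compound 4 is the one compound here that gives a true number in this assay and that number is 9.31 ug/mL. Every other compound shown stands at a single limit: the limit of > 10 ug/mL in this assay, at which 3 of the 4 values shown sit. Compound 3 gives > 10 ug/mL and this is a limit of the assay, not a number. The change from 4-fluorophenyl to 4-(hydroxymethyl)phenyl can therefore be read only as an at least 1.0-fold lower number from compound 3 to compound 4 (0.03 log units; that floor lies within the scatter) and the true distance within this pair cannot be told, so the change may do nothing or may do more than the scatter.

The compounds shown leave open what a plain methyl, an aminomethyl or a carboxylic acid would give at this same position on the ring. They also leave open whether hydroxymethyl would bring a numeric reading on the scaffolds of compound 1 or compound 2, which carry neither fluoro nor hydroxymethyl on the shared core.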